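This account rests on a few compounds, and the source may have more. Where it says the series, first, only, none or still open, it means among the compounds named here.

Compound 1 `CC(=O)c1c(O)c(C(C)=O)c(O)c(C(CCc2ccccc2)c2c(O)c(C(C)=O)c(O)c(C(C)=O)c2O)c1O`: "not determined" (no result reported)
Compound 2 `CC(=O)c1c(O)c(C(C)=O)c(O)c(C(c2c(O)c(C(C)=O)c(O)c(C(C)=O)c2O)c2ccnc3ccccc23)c1O`: 93400 nM

For the measured compounds named here, only one number is available in an ADME assay on CCRF-CEM cells (Homo sapiens) for cytotoxicity, read by MTT assay, with a stated time of 72 h; on this read-out higher numbers stand for lower toxicity in this test and lower numbers for higher toxicity in this test. Compound 2 gives 93400 nM, while compound 1 has no reported result, so compound 2 cannot be ranked against anything. It serves only as a single reference point, and it says nothing about how the series behaves as a whole.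

The next compound to be tested is compound 3 `CC(=O)c1c(O)c(C(C)=O)c(O)c(C(c2ccc(N(C)C)cc2)c2c(O)c(C(C)=O)c(O)c(C(C)=O)c2O)c1O`. It keeps the shared core of compound 2 and changes one group: 4-(dimethylamino)phenyl in place of quinolin-4-yl on a saturated chain carbon bound to two aromatic carbons. In words, this puts 4-(dimethylamino)phenyl in place of quinolin-4-yl on a saturated chain carbon bound to two aromatic carbons.

Going by the values given here, no measured pair in this assay shows what a change at this place does, so the expectation is a loose one. It is anchored only on compound 2 at 93400 nM. No step beyond the scatter is expected, with a slight lean toward lower numbers, and the expected step is a 1.6-fold lower number from compound 2 to compound 3 (0.19 log units; within the scatter). The estimate for compound 3 is 60000 nM, with an expected range from 15000 nM to 150000 nM.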

Compound 3, half-maximal cytotoxic concentration: 22100 nM
For compound 3 the middle estimate is 2.7-fold (0.43 log units) above the measured one; measured number inside the range.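

In this assay, for the compounds shown here, putting 4-(dimethylamino)phenyl in place of quinolin-4-yl on a saturated chain carbon bound to two aromatic carbons gives a 4.2-fold lower number from compound 2 to compound 3 (0.63 log units; beyond the scatter), the first readable evidence that a change at this place can move the read-out, here toward higher toxicity in this test. The step is modest, but it lies beyond the usual scatter, and it comes from a change that gives up the six-membered aromatic ring with a hetero atom and keeps one six-membered aromatic ring of carbon only, while the hydrogen-bond donor and acceptor counts stay the same. Nothing measured on these compounds explains the step.

Going by these compounds alone, this single pair cannot separate the effect of the dimethylamino group from that of the change in ring system, and compound 1 gives no step to compare with it. A plain phenyl, a 4-methoxyphenyl or a pyridin-4-yl group at the same place would be needed to tell whether the lower number follows the dimethylamino group, the ring system or neither.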